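Series notes: compound 4, furan-2-yl for benzyl

The source may hold more compounds than are shown below. What is called first, only, known or untested is meant among the compounds shown, and "the series" means these compounds.

Compound 1 `Cc1nc(N)c2nn(Cc3ccccc3)cc2n1`, compound 2 `Nc1nc(Cc2ccccc2)nc2cn(Cc3ccccc3)nc12` and compound 3 `Cn1cc2nc(Cc3ccccc3)nc(N)c2n1` share one core and have been measured in an assay on CHO cells for displacement of a labelled ligand from adenosine receptor A1 (Homo sapiens), read by scintillation counting, with a stated time of 120 min, tested at 1 uM; a lower number here means less inhibition, a higher number more inhibition at the concentration tested (going by the name of the read-out). Compound 1 gives 1%, compound 2 gives 1% and compound 3 gives 9%. Compound 2 thus stands level with compound 1, the two together the lowest of the three numbers; compound 3 is the furthest, a number 8 percentage points higher from compound 2 to compound 3 (within the scatter), still within the scatter. Compound 4 `Nc1nc(-c2ccco2)nc2cn(Cc3ccccc3)nc12` is not yet measured and differs from compound 2 in one place: furan-2-yl in place of benzyl on an aromatic carbon. The step of no change at the digits printed from compound 1 to compound 2 (within the scatter) also altered the group on this aromatic carbon and gave no change beyond the scatter; the step of a number 8 percentage points higher from compound 2 to compound 3 (within the scatter) altered the saturated chain carbon bound to an aromatic nitrogen and likewise stayed within the scatter. Nothing in the series points to a move beyond the scatter, so for compound 4 the expected step is a number 4 percentage points higher from compound 2 to compound 4 (within the scatter). Compound 4 is estimated at 5%, with a range from 0% to 25%.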

Compound 4, a percentage reported as inhibition, at one concentration (the size of the read-out at that concentration, not a potency): 32%
For compound 4 the middle estimate is 27 percentage points below the measured one, outside the stated range (above it).
By their numbers in this assay, from the lowest: compounds 1, 2 and 3 (each within the scatter of the next); then compound 4.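

Working from this assay, the aromatic carbon between two ring nitrogen atoms now shows a step beyond the scatter, with furan-2-yl in place of benzyl giving a number 31 percentage points higher from compound 2 to compound 4 (beyond the scatter) and furan-2-yl in place of methyl giving a number 31 percentage points higher from compound 1 to compound 4 (beyond the scatter) on the same carbon. The earlier exchange at this carbon, no change at the digits printed from compound 1 to compound 2 (within the scatter), involved only methyl and benzyl, so it gave no sign that this position could respond at all. Nothing at hand tells which feature of furan-2-yl lies behind the step.

The compounds shown leave open whether the step follows the ring oxygen or an aromatic ring bound directly to this carbon, which phenyl and thiophen-2-yl here would help to separate. From the compounds shown here alone, it also remains open whether furan-2-yl gives a similar step with methyl in place of benzyl on the ring nitrogen, as in compound 3.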